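Swapping Phenyl for Isopropyl on the Ring Amide Nitrogen

A few compounds are considered here, and "the series" means these few. Any claim that something is new, unique, unknown or untested is made for them only; others in the source may bear on it.

Measured compounds:
compound 1, `CN1C(=O)C(C2=NS(=O)(=O)c3cc(NS(C)(=O)=O)ccc3N2)=C(O)C2CCCC21`: "not determined" (no result reported)
compound 2, `CS(=O)(=O)Nc1ccc2c(c1)S(=O)(=O)N=C(C1=C(O)C3CCCC3N(Cc3ccc(Cl)cc3)C1=O)N2`: > 10000 nM
compound 3, `CS(=O)(=O)Nc1ccc2c(c1)S(=O)(=O)N=C(C1=C(O)C3CCCC3N(c3ccccc3)C1=O)N2`: "not determined" (no result reported)

Three compounds built on one shared core were tested in an ADME assay on Huh-7 cells (Homo sapiens) for cytotoxicity, with a stated time of 72 h; on this read-out lower numbers stand for higher toxicity in this test and higher numbers for lower toxicity in this test. For compound 2 the result is a limit of the assay and not a number, > 10000 nM; this is the limit of > 10000 nM in this assay, at which 1 of the 3 values shown sits. Compound 1 returned no result, and compound 3 likewise returned no result, so compound 3 stands nowhere on the numbers shown: no value anchors it, and the only measured entry in the whole set is the limit reached by compound 2.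

Compound 4, `CC(C)N1C(=O)C(C2=NS(=O)(=O)c3cc(NS(C)(=O)=O)ccc3N2)=C(O)C2CCCC21`, differs from compound 3 by isopropyl in place of phenyl on an amide-type nitrogen in a ring. For the measured compounds named here, no step between measured compounds exists here, so no direction and no size of change beyond the usual scatter can be expected in this assay from this swap; what is known is only that one close relative sat at the limit. On that basis compound 4 is expected to give about 15000 nM in this assay, estimated to lie between 4000 nM and 60000 nM, with a real chance that only a limit is reported.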

Compound 4, half-maximal cytotoxic concentration: > 33000 nM
Compound 4: a limit, no number (the forecaster's own chance of this, stated with the estimate: 65%); middle value at least 2.2-fold (0.34 log units) from the limit.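

In this assay compound 2 and compound 4 each gave a limit and not a number, and the step between them cannot be read. The compounds shown leave open how isopropyl compares with phenyl or 4-chlorobenzyl on the amide-type nitrogen in a ring.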